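A larger aromatic group on the same carbon

The compounds below may be only part of what the source reports. "The series", "measured", "known", "first", "only" and "open" are said of these compounds alone.

Three compounds built on one shared core have been examined in an assay for inhibition of Polyunsaturated fatty acid 5-lipoxygenase (Homo sapiens), read by HPLC, with a stated time of 10 min; on this read-out lower numbers stand for stronger inhibition and higher numbers for weaker inhibition. Compound 1 `CCCCCCC(Sc1nc(Cl)cc(Nc2nc(-c3cccc4ccccc34)cs2)n1)C(=O)O` gives 700 nM. Compound 2 `CCCCCCC(Sc1nc(Cl)cc(Nc2nc(-c3ccc([N+](=O)[O-])cc3)cs2)n1)C(=O)O` gives 1800 nM, and compound 3 `CCCCCCC(Sc1nc(Cl)cc(Nc2nc(-c3ccc(Cl)cc3Cl)cs2)n1)C(=O)O` gives 1100 nM. Among these three numbers compound 3 stands second highest, but its neighbours sit close: the gap is a 1.6-fold higher number from compound 1 to compound 3 (0.20 log units; within the scatter) and a 1.6-fold lower number from compound 2 to compound 3 (0.21 log units; within the scatter), both within the scatter, while the only step beyond the scatter is a 2.6-fold higher number from compound 1 to compound 2 (0.41 log units; beyond the scatter).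

Compound 4 `CCCCCCC(Sc1nc(Cl)cc(Nc2nc(-c3ccc(-c4ccccc4)cc3)cs2)n1)C(=O)O` differs from compound 3 in one place: 4-phenylphenyl in place of 2,4-dichlorophenyl on an aromatic carbon. Among the compounds with values here, the steps that bear on this change are the three exchanges of the aromatic group on that carbon already described. They show that swapping this group moves the number only a little, with the naphthalen-1-yl of compound 1 giving the lowest value and the 4-nitrophenyl of compound 2 the highest. The 4-phenylphenyl of compound 4 is, like naphthalen-1-yl, a group of two carbon rings, so a small step downward or none beyond the scatter is expected, giving a 1.2-fold lower number from compound 3 to compound 4 (0.09 log units; within the scatter). Compound 4 is therefore estimated at 900 nM, with a range from 400 nM to 2500 nM.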

Compound 4, half-maximal inhibitory concentration: 600 nM
The estimate for compound 4 lay 1.5-fold (0.18 log units) above the measured number, within the range that was stated.
By their numbers in this assay, from the lowest: compounds 4, 1, 3 and 2 (each within the scatter of the next, the first and the last beyond it).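

The 4-phenylphenyl group, with 12 heavy atoms against the 8 of 2,4-dichlorophenyl, adds a second six-membered aromatic carbon ring at this position, yet the numbers stay within the scatter both for 2,4-dichlorophenyl (a 1.8-fold lower number from compound 3 to compound 4 (0.26 log units; within the scatter)) and for naphthalen-1-yl (a 1.2-fold lower number from compound 1 to compound 4 (0.07 log units; within the scatter)). Two differently shaped groups of two carbon rings are thus now tolerated on this carbon, and the step away from 4-nitrophenyl (a 3.0-fold lower number from compound 2 to compound 4 (0.48 log units; beyond the scatter)) is the second beyond the scatter, after the one seen with naphthalen-1-yl. Compound 3, with a single ring, goes against a clean split by ring count. It lies within the scatter of all three others. No measurement at hand explains these steps.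

The compounds shown leave open how a plain phenyl, a pyridine ring or a small alkyl group such as methyl would behave on this carbon, and so whether the second ring matters at all. They also leave open what an amine or a carboxylic acid carried on the 4-phenylphenyl group would do to the number.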